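The source may hold more compounds than are shown below. What is called first, only, known or untested is meant among the compounds shown, and "the series" means these compounds.

Compound 1, `COc1cccc(N2CCN(C(=O)C(C)N3C(=O)CCC3=O)CC2)c1`: 50%
Compound 2, `CCC(C(=O)N1CCN(c2cccc(OC)c2)CC1)N1C(=O)CCC1=O`: 0%
Compound 3, `CCC(C(=O)N1CCN(c2cccc(C(F)(F)F)c2)CC1)N1C(=O)CCC1=O`: 50%

In a functional assay on the whole organism (strain Swiss) with Mus musculus as the target, in the maximal electroshock model, with a stated time of 0.5 h, at a dose of 300 mg/kg by the intraperitoneal route (a lower number here means a weaker effect, a higher number a stronger effect of the compound at the dose given), compound 1 gives 50%, the same value as compound 3 within the scatter, while compound 2 lies well below both: the step of a number 50 percentage points lower from compound 1 to compound 2 (beyond the scatter) is large, and so is the step back up, a number 50 percentage points higher from compound 2 to compound 3 (beyond the scatter). Compound 4, `CC(C(=O)N1CCN(c2cccc(Cl)c2)CC1)N1C(=O)CCC1=O`, has not yet been measured in this assay. It differs from compound 1 in one place: chloro in place of methoxy on an aromatic carbon. Neither measured step repeats this change. The step from compound 1 to compound 2 alters the saturated chain, not the aromatic ring, and the step from compound 2 to compound 3 replaces methoxy with trifluoromethyl rather than chloro, and starts from a compound with no activity. Within the data shown here, the only guidance is that swapping the methoxy on the aromatic carbon did move the read-out, as a number 50 percentage points higher from compound 2 to compound 3 (beyond the scatter) shows. Among the measured compounds shown here, with no closer precedent, compound 4 is expected to stay near compound 1, giving an estimated 50% (range 25% to 100%), a step of no change at the digits printed from compound 1 to compound 4 (within the scatter) that is not expected to exceed the scatter.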

Compound 4, a percentage reported as activity, at one dose (the size of the read-out at that dose, not a potency): 100%
The estimate for compound 4 lay 50 percentage points below the measured number, and the stated range covers the measured number.
By their numbers in this assay, from the lowest: compound 2; then compounds 1 and 3 (each within the scatter of the next); then compound 4.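

In this assay the step of a number 50 percentage points higher from compound 1 to compound 4 (beyond the scatter) shows that replacing methoxy at this aromatic carbon can raise the read-out from a compound that already responds, whereas the earlier replacement, the step of a number 50 percentage points higher from compound 2 to compound 3 (beyond the scatter), began from compound 2, which gives 0%. Chloro and trifluoromethyl in place of methoxy have now each given a higher number, on two different chains, although this rests on these two pairs alone. Nothing available here explains the rise.

From the compounds shown here alone, it remains open whether fluoro, bromo or a plain methyl group at this same place would also raise the read-out, and whether chloro would do so on the chain of compound 2. Going by these compounds, the read-out comes from a single dose, so how these compounds compare at other doses also remains open.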